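The source may report more compounds than this note shows. Statements on the series, on what has been measured and on what is new or still open speak of the compounds shown alone.

Measured compounds:
- compound 1 `O=c1n(Cc2cc3cnccc3n2CCCC(F)(F)F)c2cnccc2n1C1CC1` — in an ADME assay on HeLa cells (Homo sapiens) for cytotoxicity, read by ATP content, with a stated time of 3 days (a higher number here means that more compound is tolerated, a lower number that less compound is tolerated), compound 1 gives > 50000 nM, which is a limit of the assay and not a number.
- compound 2 `CS(=O)(=O)CCCn1c(Cn2c(=O)n(C3CC3)c3ccncc32)cc2cc(C(F)(F)F)ccc21` — in this assay compound 2 gives > 50000 nM, again a limit of the assay.
- compound 3 `O=c1n(Cc2cc3cc(Cl)ccc3n2CCCCO)c2cnccc2n1C1CC1` — in this assay compound 3 gives > 50000 nM, again a limit of the assay.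

Compound 1 therefore stands nowhere in particular among the three: all of them sit at the limit of > 50000 nM in this assay, at which 3 of the 3 values shown sit, and no numbered value separates one from another. No pair of these compounds differs in only one place, so no measured step is available to lean on.

Compound 4 `CS(=O)(=O)CCCn1c(Cn2c(=O)n(C3CC3)c3ccncc32)cc2cnccc21` is the next compound to be tested in this assay. Compared with compound 1 the change is methylsulfonyl in place of trifluoromethyl on a saturated chain carbon, three bonds along the chain from an aromatic nitrogen. The same chain ending, a 3-(methylsulfonyl)propyl on the aromatic nitrogen, is already present in compound 2, and compound 2 sits at the limit like compound 1. Nothing among the three measured compounds points toward a cytotoxic signal appearing.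

For compound 4 a value at the limit is expected, estimated at 50000 nM with a range from 25000 nM to 50000 nM. The step of a number no higher from compound 1 to compound 4 (the limit leaves the size open) is expected to be none beyond the scatter, with the assay most likely once more reporting only a limit.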

Compound 4, half-maximal cytotoxic concentration: > 50000 nM
Compound 4: a limit, no number; the forecaster's own chance of this, stated with the estimate: 85%; the middle value sits exactly at the limit.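

In this assay compound 4 gives > 50000 nM, a limit of the assay and not a number. Compound 1 also stands only at a limit, so no step between the two can be read, and all the compounds shown share this position: the limit of > 50000 nM in this assay, at which 4 of the 4 values shown sit.

The compounds shown leave open at what concentration, if any, cytotoxicity would appear for any of them, and whether methylsulfonyl in place of trifluoromethyl would alter it.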